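Notes on a para substituent swap in this series

This account rests on a few compounds, and the source may have more. Where it says the series, first, only, none or still open, it means among the compounds named here.

Measured so far in a functional assay on BMDM cells (Mus musculus, strain C57BL/6) for inhibition, with a stated time of 2 days; on this read-out higher numbers stand for weaker inhibition and lower numbers for stronger inhibition:
compound 1 `CCOC(=O)c1sc(NC(=O)Cn2cc(-c3ccc(OC)cc3)nn2)nc1C`: 2330 nM
compound 2 `CCOC(=O)c1sc(NC(=O)Cn2cc(-c3ccc([N+](=O)[O-])cc3)nn2)nc1C`: 1840 nM

Compound 2 has the lower of the two numbers, but its nearest neighbour is compound 1 and the step of a 1.3-fold lower number from compound 1 to compound 2 (0.10 log units; within the scatter) is within the scatter, so the two compounds are not separated on this read-out. Both differ only at the same aromatic carbon, and that exchange of one group for another there left the number essentially unchanged.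

Compound 3 `CCOC(=O)c1sc(NC(=O)Cn2cc(-c3ccc(Cl)cc3)nn2)nc1C` is not yet measured. Its change from compound 2 is chloro in place of nitro on an aromatic carbon. Going by the values given here, the only step that bears on it is the one from compound 1 to compound 2, which touched the same aromatic carbon and gave no movement beyond the scatter. Among the compounds with values here, no other measured pair informs the swap to chloro. The expectation for compound 3 in this assay is therefore a step of a 1.1-fold higher number from compound 2 to compound 3 (0.04 log units; within the scatter), that is nothing beyond the scatter in either direction. Compound 3 is estimated at 2000 nM, with a range from 900 nM to 4500 nM.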

Compound 3, half-maximal inhibitory concentration: 180 nM
Beside the measured number, compound 3's estimate is 11-fold (1.05 log units) above it; measured number outside the range, below it.
By their numbers in this assay, from the lowest: compound 3; then compounds 2 and 1 (each within the scatter of the next).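

In this assay the aromatic carbon para to a large group proves sensitive to what it carries: chloro in place of nitro gives a 10-fold lower number from compound 2 to compound 3 (1.01 log units; beyond the scatter) and chloro in place of methoxy gives a 13-fold lower number from compound 1 to compound 3 (1.11 log units; beyond the scatter) on the same core. The flat reading between methoxy and nitro therefore described only those two groups and not the position as a whole, and compound 3 now stands clearly apart from both, with the strongest inhibition of the three on this read-out. Nothing available explains why chloro separates from the other two groups at this carbon.

Three groups at a single carbon cannot show whether this step is particular to chloro or is shared by fluoro, bromo, methyl or trifluoromethyl at the same place. From the compounds shown here alone, it also remains open whether the 4-chlorophenyl group keeps its advantage when the rest of the molecule changes, for example when the ethyl ester gives way to a carboxylic acid or an amide.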